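A Pyridinyl Sulfoxide Variant in a Weak Antiproliferative Series

The source may hold more compounds than are shown below. What is called first, only, known or untested is meant among the compounds shown, and "the series" means these compounds.

Compound 1 `CC(O)(C[S+]([O-])c1ccc(F)cc1F)C(=O)Nc1ccc([N+](=O)[O-])cc1C(F)(F)F` is tested in a functional assay on CWR22R cells (Homo sapiens) for antiproliferative activity (a lower number here means a stronger inhibitor, a higher number a weaker inhibitor), where compound 1 gives 51100 nM. Two related compounds sit beside it. Compound 2 `CC(O)(C[S+]([O-])c1ccc(OC(F)(F)F)cc1)C(=O)Nc1ccc(C#N)c(C(F)(F)F)c1` gives 41200 nM, a number within the usual scatter of compound 1, so the two cannot be told apart. Compound 3 `CC(O)(C[S+]([O-])c1ccc(C(F)(F)F)cn1)C(=O)Nc1ccc(C#N)c(C(F)(F)F)c1` has been measured more than once, and compound 3 gives 65500 nM; 77000 nM (2 entries); its repeat entries the several entries of compound 3 in this assay, 65500 nM; 77000 nM (2 entries) show how far such weak numbers wander on their own. Among the measured compounds shown here, all three are feeble inhibitors, and no pair among them differs in just a single place, so no measured step exists.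

Compound 4 `CC(O)(C[S+]([O-])c1ccccn1)C(=O)Nc1ccc([N+](=O)[O-])cc1C(F)(F)F` has not yet been measured. It differs from compound 1 in one place: pyridin-2-yl in place of 2,4-difluorophenyl on a sulfur. The closest point of comparison is compound 3, which also carries a nitrogen-containing ring on its sulfur and gives 65500 nM; 77000 nM (2 entries). The step of a 1.2-fold higher number from compound 1 to compound 4 (0.07 log units; within the scatter) is expected to be small, a slightly weaker result or none beyond the scatter. Compound 4 is estimated at 60000 nM, within 25000 nM to 150000 nM.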

Compound 4, half-maximal inhibitory concentration: > 100000 nM
Compound 4 gave a limit, no number (the forecaster's own chance of this, stated with the estimate: 15%); middle value at least 1.6-fold (0.22 log units) away from the limit.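

Among the compounds shown here, this is the first single change that can be read. In this assay compound 4 gives > 100000 nM and that value is a limit of the assay, not a number. Putting pyridin-2-yl in place of 2,4-difluorophenyl on a sulfur gives an at least 1.9-fold higher number from compound 1 to compound 4 (0.29 log units; that floor lies within the scatter) so the swap shows no gain in this already weak series, yet the floor of the step does not clear the scatter and a real loss cannot be claimed.

As far as these compounds go, how far compound 4 truly lies from compound 1 stays unknown because only a limit is available: the limit of > 100000 nM in this assay, at which 1 of the 4 values shown sits. A plain phenyl or a pyridin-3-yl ring on this sulfur would be needed to separate the effect of removing the two fluorines from that of adding the ring nitrogen, and the compounds shown include neither.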